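The source may report more compounds than this note shows. Statements on the series, on what has been measured and on what is new or still open speak of the compounds shown alone.

Values in a functional assay on MDA-MB-231 cells (Homo sapiens) for cytotoxicity, read by MTT assay, with a stated time of 24 h; a lower number here means a stronger inhibitor, a higher number a weaker inhibitor:
- compound 1 `C[C@@H](N)C(=O)NCc1nnc(-c2ccccc2)o1`: 230 nM
- compound 2 `C[C@@H](N)C(=O)NCc1nnc(-c2ccc(F)cc2)o1`: 247 nM
- compound 3 `NCC(=O)NCc1nnc(-c2ccc([N+](=O)[O-])cc2)o1`: 276 nM

Compound 3, at 276 nM, lies within the scatter of both other measured compounds, so no order can be read among the three. Still unmeasured is compound 4 `C[C@@H](N)C(=O)NCc1nnc(-c2ccc([N+](=O)[O-])cc2)o1`. It differs from compound 3 by methyl in place of hydrogen on a saturated chain carbon bound to an amine nitrogen and a carbonyl carbon, which is methyl in place of hydrogen on a saturated chain carbon bound to an amine nitrogen and a carbonyl carbon.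

Among the measured compounds shown here, the only measured single-place step, a 1.1-fold higher number from compound 1 to compound 2 (0.03 log units; within the scatter), is fluoro in place of hydrogen on an aromatic carbon. That is a different change in a different place, and it stays within the scatter. For the measured compounds named here, no measured step isolates the methyl change. Indirect support comes from the values alone: compound 1 gives 230 nM and compound 2 gives 247 nM, both with the 1-aminoethyl group, while compound 3, with aminomethyl, is also within the scatter of them. No step beyond the scatter is therefore expected in this assay, and no direction is favoured. The expected step is a 1.1-fold lower number from compound 3 to compound 4 (0.04 log units; within the scatter). Compound 4 is estimated at 250 nM, with an expected range of 140 nM to 450 nM.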

Compound 4, half-maximal inhibitory concentration: 261 nM
Compound 4: middle estimate off by 1.0-fold (0.02 log units), on the low side, within the range that was stated.
By their numbers in this assay, from the lowest: compounds 1, 2, 4 and 3 (each within the scatter of the next).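

In this assay, among the compounds shown here, the step of a 1.1-fold lower number from compound 3 to compound 4 (0.02 log units; within the scatter) is the first to isolate methyl in place of hydrogen on a saturated chain carbon bound to an amine nitrogen and a carbonyl carbon, and with nitro held constant, aminomethyl to 1-aminoethyl stays within the scatter. With 1-aminoethyl held constant, the aromatic carbon now offers two further comparisons: nitro in place of fluoro gives a 1.1-fold higher number from compound 2 to compound 4 (0.02 log units; within the scatter) and nitro in place of hydrogen gives a 1.1-fold higher number from compound 1 to compound 4 (0.05 log units; within the scatter), and both also stay within the scatter, so hydrogen, fluoro and nitro at that carbon cannot be told apart in this series. No measurement accompanies these values that could account for the absence of a larger step.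

On these data alone, it remains open whether an isopropyl or benzyl group on the same saturated chain carbon, or a methoxy or carboxylic acid in place of nitro on the aromatic carbon, would give a step beyond the scatter. As far as these compounds go, an acetamide in place of the amine is equally open, as the amine is present in all four compounds.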